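Working notes on compounds 1 to 4

The source may hold more compounds than are shown below. What is called first, only, known or untested is meant among the compounds shown, and "the series" means these compounds.

Measured so far in a functional assay on HCT-116 cells (Homo sapiens) for cytotoxicity, read by resazurin assay, with a stated time of 48 h; on this read-out lower numbers stand for an effect already at smaller amounts and higher numbers for an effect only at larger amounts of compound:
compound 1 `O=C(/C=C/c1ccco1)c1ccc(NC(=O)c2cccs2)cc1` gives 33000 nM
compound 2 `Nc1ccc(C(=O)/C=C/c2ccccc2)cc1` gives 27000 nM
compound 3 `O=C(/C=C/c1ccccc1)c1ccc(NC(=O)c2ccccc2)cc1` gives 17000 nM

Compound 3 has the lowest of the three numbers, but its gap to compound 2 and its gap to compound 1 both lie within the scatter, so no order among the three can be read from these values. For the measured compounds named here, the only step between compounds that differ in a single place is a 1.6-fold lower number from compound 2 to compound 3 (0.20 log units; within the scatter), benzoyl in place of hydrogen on a nitrogen on an aromatic ring, and that step also stays within the scatter. Compound 4 `O=C(/C=C/c1cccc([N+](=O)[O-])c1)c1ccc(NC(=O)c2ccccc2)cc1` differs from compound 3 by nitro in place of hydrogen on an aromatic carbon, placed on an aromatic carbon of a six-membered aromatic ring of carbon only, meta to a large group; cut one bond further out, the change reads phenyl to 3-nitrophenyl. Going by the values given here, no measured step touches that ring, so the data give no direction for this change. The step in this assay is therefore expected to be a 1.1-fold lower number from compound 3 to compound 4 (0.05 log units; within the scatter), without a move beyond the scatter. For compound 4 the estimate is 15000 nM, with a range from 6000 nM to 40000 nM.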

Compound 4, half-maximal effective concentration: 4100 nM
For compound 4 the middle estimate is 3.7-fold (0.56 log units) above the measured one, outside the stated range (below it).
By their numbers in this assay, from the lowest: compound 4; then compounds 3, 2 and 1 (each within the scatter of the next).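

In this assay, for the compounds shown here, nitro in place of hydrogen on an aromatic carbon, meta to a large group, gives a 4.1-fold lower number from compound 3 to compound 4 (0.62 log units; beyond the scatter), and this is the first step to go beyond the scatter. Going by these compounds alone, the earlier step, a 1.6-fold lower number from compound 2 to compound 3 (0.20 log units; within the scatter), changed the nitrogen on the aromatic ring and stayed within the scatter, so this aromatic ring, changed from phenyl to 3-nitrophenyl, is the first place where a single change moves the number beyond the scatter. Nothing measured on the compounds themselves bears on what lies behind this step.

The compounds shown leave open whether the lower number is tied to nitro itself or would also follow with an amine, a methoxy group or a chlorine atom in the same place. They also leave open whether nitro elsewhere on this ring would give a similar step.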